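The compounds below may be only part of what the source reports. "The series", "measured", "known", "first", "only" and "open" are said of these compounds alone.

Measured so far in a functional assay on BGC-823 cells (Homo sapiens) for inhibition, read by CCK-8 assay, with a stated time of 48 h; on this read-out lower numbers stand for stronger inhibition and higher numbers for weaker inhibition:
compound 1, `Cc1ccc(C2=NN(C3=NC(=O)CS3)C(c3ccc4ccccc4c3)C2)cc1`: 7790 nM
compound 2, `Cc1ccc(C2=NN(C3=NC(c4ccccc4)CS3)C(c3ccc4ccccc4c3)C2)cc1`: 8940 nM
compound 3, `O=C1CSC(N2N=C(c3ccc(Br)cc3)CC2c2ccc3ccccc3c2)=N1`: 11700 nM

Compound 2 stands second highest of the three numbers. Its nearest neighbour is compound 1, with a 1.1-fold higher number from compound 1 to compound 2 (0.06 log units; within the scatter), and its furthest is compound 3, whose value differs from it only within the scatter, so the three compounds are not separated in this assay.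

Compound 4, `Clc1ccc(C2=NN(C3=NC(c4ccccc4)CS3)C(c3ccc4ccccc4c3)C2)cc1`, is the next to be measured. It differs from compound 2 at one place: chloro in place of methyl on an aromatic carbon. For the measured compounds named here, of the measured steps, the one from compound 1 to compound 3 is the closest parallel, since there too methyl was exchanged at the same aromatic carbon, and that step gave a 1.5-fold higher number from compound 1 to compound 3 (0.18 log units; within the scatter). The other step, from compound 1 to compound 2, concerns a different part of the molecule and so bears only on where compound 2 itself stands.

On this basis compound 4 is expected to sit near compound 2, with no step beyond the scatter, perhaps a slightly higher number as for compound 3. The step expected from compound 2 to compound 4 is a 1.2-fold higher number from compound 2 to compound 4 (0.07 log units; within the scatter). Compound 4 is therefore estimated at 10500 nM, with a range from 5000 nM to 22000 nM.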

Compound 4, half-maximal inhibitory concentration: 14600 nM
For compound 4 the middle estimate is 1.4-fold (0.14 log units) below the measured one; measured number inside the range.
By their numbers in this assay, from the lowest: compounds 1, 2, 3 and 4 (each within the scatter of the next).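

In this assay, the change from 4-methylphenyl to 4-chlorophenyl gives a 1.6-fold higher number from compound 2 to compound 4 (0.21 log units; within the scatter), so a second halogen at this aromatic carbon, para to a large group, also leaves the number within the scatter of its methyl partner. The earlier exchange at this place, a 1.5-fold higher number from compound 1 to compound 3 (0.18 log units; within the scatter), involved bromo and the partner with the smaller group on the ring amine nitrogen, whereas this one involves chloro and the partner carrying the phenyl-bearing ring, so methyl can give way to a halogen with either group present without a step beyond the scatter. No measurement bears on why this step has the size it has.

The compounds shown span too narrow a range to tell whether any group at this place can move the number beyond the scatter, and a methoxy group, an amine or a carboxylic acid there would test this. They also leave open how chloro behaves with the smaller group on the ring amine nitrogen, and how bromo behaves with the larger one.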